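A few compounds are considered here, and "the series" means these few. Any claim that something is new, unique, unknown or untested is made for them only; others in the source may bear on it.

Compound 1 `CNCC(=O)N1N=C(c2cc3ccccc3oc2=O)CC1c1ccccc1`: 2300 nM
Compound 2 `O=C(CNC1CC1)N1N=C(c2cc3ccccc3oc2=O)CC1c1ccccc1`: 28500 nM

In a functional assay on PC-3 cells (Homo sapiens) for cytotoxicity, read by MTT assay, with a stated time of 48 h (a lower number here means a stronger inhibitor, a higher number a weaker inhibitor), compound 1 gives 2300 nM, while compound 2 gives 28500 nM. Compound 2 thus holds the higher of the two numbers, with a 12-fold higher number from compound 1 to compound 2 (1.09 log units; beyond the scatter). Compound 3 `CC1CCCCN1CC(=O)N1N=C(c2cc3ccccc3oc2=O)CC1c1ccccc1` carries a further change at the same place: 2-methylpiperidin-1-yl in place of cyclopropylamino on a saturated chain carbon bound to a carbonyl carbon. Within the data shown here, the only step on record, a 12-fold higher number from compound 1 to compound 2 (1.09 log units; beyond the scatter), was large and went toward weaker inhibition when the amine substituent grew; it is the sole guide here, and it does not cover the loss of the amine hydrogen or the ring now formed with the nitrogen. On that basis compound 3 is expected to stay near compound 2 or move modestly higher, so that a 1.2-fold higher number from compound 2 to compound 3 (0.09 log units; within the scatter) is estimated, giving an expected value for compound 3 of 35000 nM with a range from 9000 nM to 120000 nM.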

Compound 3, half-maximal inhibitory concentration: 36300 nM
The estimate for compound 3 lay 1.0-fold (0.02 log units) below the measured number; the measured number falls inside the stated range.
By their numbers in this assay, from the lowest: compound 1; then compounds 2 and 3 (each within the scatter of the next).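

In this assay, the change to 2-methylpiperidin-1-yl on a saturated chain carbon bound to a carbonyl carbon stays within the scatter (a 1.3-fold higher number from compound 2 to compound 3 (0.11 log units; within the scatter)), even though cyclopropylamino carries a hydrogen-bond donor and the entering group carries none. Against methylamino, the same group gives a large step (a 16-fold higher number from compound 1 to compound 3 (1.20 log units; beyond the scatter)), so compound 1 stands apart from both compound 2 and compound 3, whose amine groups differ in ring size and in the amine hydrogen. Nothing available explains this outcome.

The compounds shown leave open how dimethylamino, an unsubstituted piperidin-1-yl or a morpholin-4-yl group would read at this place. They also leave open whether the methyl on the piperidine ring contributes anything to the number for compound 3.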